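The compounds below may be only part of what the source reports. "The series", "measured", "known", "first", "only" and "open" are said of these compounds alone.

Compound 1 `O=C(/C=C\Nc1ccc(F)cc1)c1cn(-c2ccccc2)nc1-c1ccccc1` gives 10200 nM in a functional assay on U-87MG ATCC cells (Homo sapiens) for antiproliferative activity, read by MTT assay, with a stated time of 48 h; on this read-out higher numbers stand for weaker inhibition and lower numbers for stronger inhibition.
Compound 2 `O=C(/C=C\Nc1ccc(F)cc1)c1cn(-c2ccccc2)nc1-c1ccc(Cl)cc1` gives 17900 nM.
Compound 3 `COc1ccc(-c2nn(-c3ccccc3)cc2C(=O)/C=C\Nc2ccc(F)cc2)cc1` gives 8910 nM.

Compound 3 carries the lowest of the three numbers, yet its gaps to the others, a 1.1-fold lower number from compound 1 to compound 3 (0.06 log units; within the scatter) and a 2.0-fold lower number from compound 2 to compound 3 (0.30 log units; within the scatter), both lie within the scatter, so no order among the three can be claimed. Compound 4 `COc1ccc(-c2nn(-c3ccccc3)cc2C(=O)/C=C\Nc2cc(OC)c(OC)c(OC)c2)cc1` differs from compound 3 by 3,4,5-trimethoxyphenyl in place of 4-fluorophenyl on an amine nitrogen. The measured steps, a 1.8-fold higher number from compound 1 to compound 2 (0.24 log units; within the scatter) among them, all concern a substituent on an aromatic carbon of the other ring and none touches the amine nitrogen, so none bears directly on this change; each stayed within the scatter. The step from compound 3 to compound 4 is therefore expected to stay small, a 1.5-fold lower number from compound 3 to compound 4 (0.17 log units; within the scatter). Compound 4 is estimated at 6000 nM in this assay, within a range from 1500 nM to 25000 nM.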

Compound 4, half-maximal inhibitory concentration: > 50000 nM
Compound 4 ended at the assay's limit (the forecaster's own chance of this, stated with the estimate: 5%); middle value at least 8.3-fold (0.92 log units) from the limit.
By their numbers in this assay, from the lowest: compounds 3, 1 and 2 (each within the scatter of the next). At a limit, above all of these: compound 4.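

At the amine nitrogen, 3,4,5-trimethoxyphenyl in place of 4-fluorophenyl moves the read-out in this assay beyond the scatter, with an at least 5.6-fold higher number from compound 3 to compound 4 (0.74 log units; beyond the scatter), whereas every earlier step, all on an aromatic carbon, stayed within it. This position therefore responds to a change of group in a way those steps did not show, and here the change weakens inhibition. The reading for compound 4 is a limit and not a number: the limit of > 50000 nM in this assay, at which 1 of the 4 values shown sits.

On these data alone, the full size of the step remains open. So does whether a plain phenyl or a 4-methoxyphenyl group on this amine nitrogen would keep the activity of compound 3.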